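Amide-nitrogen substituents on the shared core

A few compounds are considered here, and "the series" means these few. Any claim that something is new, unique, unknown or untested is made for them only; others in the source may bear on it.

Three compounds with one shared core differ only at the amide-type nitrogen. In a functional assay on MCF7 cells (Homo sapiens) for antiproliferative activity, read by MTT assay, with a stated time of 24 h (a lower number here means a stronger inhibitor, a higher number a weaker inhibitor), compound 1 `CCn1c(C(=O)N[C@@H](CC(=O)OC)C(=O)OC)ccc1C(CC)(CC)c1ccc(OCS(=O)(=O)c2ccccc2)c(C)c1` gives > 50000 nM, which is a limit of this assay rather than a number. Compound 2 `CCN(CC)CCNC(=O)c1ccc(C(CC)(CC)c2ccc(OCS(=O)(=O)c3ccccc3)c(C)c2)n1CC` gives 4680 nM in this assay, and compound 3 `CCn1c(C(=O)N[C@H](CO)C(C)C)ccc1C(CC)(CC)c1ccc(OCS(=O)(=O)c2ccccc2)c(C)c1` gives 25500 nM, the highest of the two numbers shown; the step of a 5.4-fold higher number from compound 2 to compound 3 (0.74 log units; beyond the scatter) separates them.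

Compound 4 `CCn1c(C(=O)NC2(C(=O)O)CC2)ccc1C(CC)(CC)c1ccc(OCS(=O)(=O)c2ccccc2)c(C)c1` differs from compound 3 by 1-carboxycyclopropyl in place of 1-(hydroxymethyl)-2-methylpropyl on an amide-type nitrogen. Going by the values given here, the steps that bear on this position are an at least 10-fold lower number from compound 1 to compound 2 (1.02 log units; beyond the scatter) and a 5.4-fold higher number from compound 2 to compound 3 (0.74 log units; beyond the scatter), whereas an at least 1.9-fold lower number from compound 1 to compound 3 (0.29 log units; that floor lies within the scatter). Both neutral substituents gave a high number or a limit, so compound 4 is expected to move by a 1.2-fold higher number from compound 3 to compound 4 (0.07 log units; within the scatter). Compound 4 is therefore estimated at 30000 nM, within a range from 9000 nM to 60000 nM.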

Compound 4, half-maximal inhibitory concentration: 41200 nM
Beside the measured number, compound 4's estimate is 1.4-fold (0.14 log units) below it; the range from low to high includes it.
By their numbers in this assay, from the lowest: compound 2; then compounds 3 and 4 (each within the scatter of the next). At a limit, above all of these: compound 1.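

In this assay, the step for 1-carboxycyclopropyl in place of 1-(hydroxymethyl)-2-methylpropyl on the amide-type nitrogen is a 1.6-fold higher number from compound 3 to compound 4 (0.21 log units; within the scatter), so these two substituents cannot be told apart. Among the measured numbers, the 2-(diethylamino)ethyl substituent alone stands apart, now also with an 8.8-fold higher number from compound 2 to compound 4 (0.94 log units; beyond the scatter). The remaining step, an at least 1.2-fold lower number from compound 1 to compound 4 (0.08 log units; that floor lies within the scatter), gives a floor and cannot be read as a size. Compound 1 is at a limit: the limit of > 50000 nM in this assay, at which 1 of the 4 values shown sits.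

Still open, on these data alone, is whether the lower number of compound 2 depends on the diethylamino end or on the ethyl chain that carries it. A dimethylamino or pyrrolidine end group, or a longer chain to the same amine, would test this.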